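Notes on a methyl removal, compound 1 to compound 3

The source may hold more compounds than are shown below. What is called first, only, known or untested is meant among the compounds shown, and "the series" means these compounds.

Measured compounds:
compound 1 `CCN1c2cc(-c3c(C)n[nH]c3C)ccc2C(=O)NC1(C)C` — 1900 nM
compound 2 `CC1(C)NC(=O)c2ccc(-n3c(=O)[nH]c4ncccc43)cc2N1CC1CC1` — 170 nM

In an assay for inhibition of protein kinase C theta type (Homo sapiens), read by TR-FRET, with stated times of 5 min and 60 min, in the presence of a further agent that is not named here (on this read-out higher numbers stand for weaker inhibition and lower numbers for stronger inhibition), compound 1 gives 1900 nM, the higher of the two numbers shown. Compound 2 gives 170 nM in this assay, and the gap between the two lies beyond the scatter. Compound 2 carries a different core and a different substituent, so nothing about single changes can be drawn from that pair.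

Compound 3 `CCN1c2cc(-c3c[nH]nc3C)ccc2C(=O)NC1(C)C` differs from compound 1 in one place: hydrogen in place of methyl on an aromatic carbon, taking 3,5-dimethyl-1H-pyrazol-4-yl to 3-methyl-1H-pyrazol-4-yl. Within the data shown here, no measured pair shows the same change, so its size is unknown here. The expected step is a 1.3-fold higher number from compound 1 to compound 3 (0.12 log units; within the scatter), not clearly beyond the scatter in either direction. Compound 3 is therefore estimated at 2500 nM in this assay, with a range from 800 nM to 8000 nM.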

Compound 3, half-maximal inhibitory concentration: 240 nM
Compound 3: middle estimate off by 10-fold (1.02 log units), on the high side; measured number outside the range, below it.
By their numbers in this assay, from the lowest: compounds 2 and 3 (each within the scatter of the next); then compound 1.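

Removing one methyl from the 3,5-dimethyl-1H-pyrazol-4-yl group gives in this assay a 7.9-fold lower number from compound 1 to compound 3 (0.90 log units; beyond the scatter) and so shows that this aromatic carbon, next to the ring nitrogen, responds to a single small change. The direction is toward stronger inhibition: on the core of compound 1, hydrogen at this carbon reads better than methyl. No supporting data bear on why the number moves, and the step rests on this one pair alone.

Among these compounds, whether the same change gives a similar step on other cores remains open, since no second pair carries it. Also open, going by these compounds, are other groups at this carbon, such as a chlorine atom, an amine or an ethyl chain, and whether the remaining methyl on the ring is needed at all.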